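Adding Chloro to a Series Sitting at the Assay Limit

The compounds below may be only part of what the source reports. "The series", "measured", "known", "first", "only" and "open" are said of these compounds alone.

Compound 1 `CC1(C)CC(NC(=O)C2=NS(=O)(=O)c3ccccc3N2)c2cc(F)ccc2O1`, compound 2 `CC1(C)CC(NC(=O)C2=NS(=O)(=O)c3ccccc3N2)c2cc(Br)ccc2O1` and compound 3 `CC1(C)CC(NC(=O)C2=NS(=O)(=O)c3ccccc3N2)c2cc([N+](=O)[O-])ccc2O1` share one core and differ only in a single group on an aromatic carbon. In a functional assay on aorta (Rattus norvegicus, strain Wistar) for inhibition (a higher number here means that more compound is needed for the effect, a lower number that less compound is needed), compound 1 gives only a limit, > 30000 nM. Compound 2 likewise gives only a limit in this assay, > 30000 nM. Compound 3 too gives only a limit in this assay, > 30000 nM. The steps a step that the two limits leave unreadable from compound 1 to compound 2, a step that the two limits leave unreadable from compound 1 to compound 3 and a step that the two limits leave unreadable from compound 2 to compound 3 cannot be sized because of the limit of > 30000 nM in this assay, at which 3 of the 3 values shown sit. Compound 4 `CC1(C)CC(NC(=O)C2=NS(=O)(=O)c3cc(Cl)ccc3N2)c2cc([N+](=O)[O-])ccc2O1` carries chloro in place of hydrogen on an aromatic carbon. Going by the values given here, no measured step bears on this change, and nothing shows whether compound 3 stands far past the limit or just at it. Compound 4 is expected to remain at or near that limit, an estimated step that the limit leaves unreadable from compound 3 to compound 4. The estimate for compound 4 is 40000 nM, ranging from 10000 nM to 150000 nM.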

Compound 4, half-maximal effective concentration: > 30000 nM
Compound 4: a limit, no number; the forecaster's own chance of this, stated with the estimate: 80%; the middle value is on the limit's open side.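

Going by these compounds alone, no step from compound 3 to compound 4 can be read, because both values are limits rather than numbers: the limit of > 30000 nM in this assay, at which 4 of the 4 values shown sit. In this assay the compounds shown leave open how far each stands past its limit, and so whether chloro in place of hydrogen changes anything.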